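The compounds below may be only part of what the source reports. "The series", "measured", "known", "first", "only" and "open" are said of these compounds alone.

Compound 1 `Cn1cc(-c2ccncc2)c(-c2ccc(OCc3ccc4ccccc4c3)cc2)n1` and compound 2 `Cn1cc(-c2ccncc2)c(-c2ccc(OCB3C=Cc4ccccc4N3)cc2)n1` share a core and differ in one place: a group of 10 heavy atoms (8 carbon, 1 boron, 1 nitrogen; one six-membered non-aromatic ring with 2 hetero atoms, one six-membered aromatic ring of carbon only) in place of a group of 10 heavy atoms (10 carbon; 2 six-membered aromatic rings of carbon only), on a saturated chain carbon bound to an oxygen on an aromatic ring. In an ADME assay (liver) for metabolic stability, with Liver microsome (Rattus norvegicus) as the target, using microsomes (a higher number here means faster removal of the compound, a lower number slower removal), compound 1 gives 83.3 mL/min/kg, and compound 2 gives 41.7 mL/min/kg, so the change made a 2.0-fold lower number from compound 1 to compound 2 (0.30 log units; within the scatter). Compound 3 `CN(C(=O)c1csc(-c2cccnc2)n1)c1ccc(OCc2ccc3ccccc3c2)cc1` has a different core; the difference between the two cores is not broken down here. In this assay compound 3 gives only a limit, > 283 mL/min/kg, which is the limit at which (the limit of > 283 mL/min/kg in this assay, at which 1 of the 3 values shown sits). Compound 4 `CN(C(=O)c1csc(-c2cccnc2)n1)c1ccc(OCB2C=Cc3ccccc3N2)cc1` has not been measured. It differs from compound 3 in the same way that compound 2 differs from compound 1: a group of 10 heavy atoms (8 carbon, 1 boron, 1 nitrogen; one six-membered non-aromatic ring with 2 hetero atoms, one six-membered aromatic ring of carbon only) in place of a group of 10 heavy atoms (10 carbon; 2 six-membered aromatic rings of carbon only), on a saturated chain carbon bound to an oxygen on an aromatic ring. The step from compound 3 to compound 4 is expected to be about an at least 1.4-fold lower number from compound 3 to compound 4 (0.15 log units; that floor lies within the scatter), resting on the step that the same change made from compound 1 to compound 2 in this assay, a 2.0-fold lower number from compound 1 to compound 2 (0.30 log units; within the scatter), though the limit for compound 3 makes the starting point uncertain. On that basis the clearance of compound 4 in this assay is estimated at 200 mL/min/kg, within a range of 90 mL/min/kg to 450 mL/min/kg.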

Compound 4, clearance: > 283 mL/min/kg
Compound 4 was reported as a limit (the forecaster's own chance of this, stated with the estimate: 40%); middle value at least 1.4-fold (0.15 log units) away from the limit.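

In this assay, compound 3 and compound 4 are both reported only as limits, so no step between them can be read: the limit of > 283 mL/min/kg in this assay, at which 2 of the 4 values shown sit.

The compounds shown leave open whether replacing naphthalen-2-yl with the boron-containing group changes clearance on the core of compound 3 at all, and in which direction.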